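Heteroaryl swap on the aromatic carbon: compound 3 to compound 4

A few compounds are considered here, and "the series" means these few. Any claim that something is new, unique, unknown or untested is made for them only; others in the source may bear on it.

Compound 3 `c1ccc(-c2ccncn2)c(OCC2=NCCN2)c1` stands at a limit in a functional assay for activation of Alpha-1D adrenergic receptor (Homo sapiens), read by calcium flux; a higher number here means that more compound is needed for the effect, a lower number that less compound is needed: in this assay compound 3 gives < 100000 nM, a limit and not a number. Compound 2 `c1ccc(-c2ccncc2)c(OCC2=NCCN2)c1` likewise gives only a limit, < 100000 nM, in this assay. Among the measured compounds shown here, compound 1 `c1cncc(-c2ccccc2OCC2=NCCN2)c1` gives 158 nM in this assay and is the only numeric value in the set. The steps a step that the limit leaves unreadable from compound 1 to compound 2 and a step that the limit leaves unreadable from compound 1 to compound 3 have no readable size, and the same holds for a step that the two limits leave unreadable from compound 2 to compound 3, because the limit of < 100000 nM in this assay, at which 2 of the 3 values shown sit, leaves their sizes unreadable.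

Compound 4 `c1coc(-c2ccccc2OCC2=NCCN2)c1` differs from compound 3 by furan-2-yl in place of pyrimidin-4-yl on an aromatic carbon. For the measured compounds named here, no measured step covers a six-membered to five-membered heteroaryl exchange at this carbon, so nothing in the set fixes the size or direction of the step. Going by the values given here, the only anchor is compound 1, which shows that a heteroaryl at this carbon can reach a measurable value, while compounds 2 and 3 show that others do not. Compound 4 is therefore expected to fall near 2000 nM, within a wide range from 100 nM to 50000 nM. The expected step is a step that the limit leaves unreadable from compound 3 to compound 4, though against a limit it cannot be read.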

Compound 4, half-maximal effective concentration: < 100000 nM
Compound 4: no number, only a limit; the forecaster's own chance of this, stated with the estimate: 40%; the middle value does not contradict the limit.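

Among the compounds shown here, no step from compound 1, compound 2 or compound 3 to compound 4 can be read in this assay, because of this: the limit of < 100000 nM in this assay, at which 3 of the 4 values shown sit. Still open, going by these compounds, is how far compound 2, compound 3 and compound 4 lie from compound 1, and whether they differ from one another.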